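This account rests on a few compounds, and the source may have more. Where it says the series, first, only, none or still open, it means among the compounds named here.

Measured so far:
- compound 1, `CC(C)(C)Cc1c(-c2cc(F)ccc2F)sc(N)c1C(=O)c1ccc(Cl)cc1`: 3%
- compound 2, `COc1ccccc1-c1sc(N)c(C(=O)c2ccc(Cl)cc2)c1CC(C)(C)C`: 1%
- compound 3, `Cc1cccc(-c2sc(N)c(C(=O)c3ccc(Cl)cc3)c2CC(C)(C)C)c1`: 1%

In an assay on CHO cells for displacement of a labelled ligand from adenosine receptor A1 (Homo sapiens), read by scintillation counting, tested at 10 uM (a higher number here means more inhibition at the concentration tested (going by the name of the read-out), a lower number less inhibition), compound 3 gives 1%. This sits level with compound 2, as the step of no change at the digits printed from compound 2 to compound 3 (within the scatter) shows, and the gap to compound 1, a number 2 percentage points lower from compound 1 to compound 3 (within the scatter), is also within the scatter. All three compounds therefore show essentially no inhibition at the concentration tested, with no difference between them that can be trusted.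

Compound 4, `Cc1ccccc1-c1sc(N)c(C(=O)c2ccc(Cl)cc2)c1CC(C)(C)C`, keeps the same atoms as compound 3 but joins them differently: 2-methylphenyl in place of 3-methylphenyl on an aromatic carbon. Within the data shown here, every measured step so far changes the pendant phenyl group in the same position of the shared core: a number 2 percentage points lower from compound 1 to compound 2 (within the scatter), a number 2 percentage points lower from compound 1 to compound 3 (within the scatter) and no change at the digits printed from compound 2 to compound 3 (within the scatter), each within the scatter. Three different aryl groups have given the same flat result, so a further change of the same kind is expected to give no step beyond the scatter in this assay; the expected step is a number 1 percentage points higher from compound 3 to compound 4 (within the scatter). Compound 4 is estimated at 2%, with a range from 0% to 10%.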

Compound 4, a percentage reported as inhibition, at one concentration (the size of the read-out at that concentration, not a potency): 1%
Compound 4: the middle estimate sits 1 percentage points above what was measured; the measured number falls inside the stated range.
By their numbers in this assay, from the lowest: compounds 2, 3, 4 and 1 (each within the scatter of the next).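

Moving the methyl group around the phenyl ring, on the aromatic carbon next to the ring sulfur, changes how the atoms are joined but not which atoms are present, and in this assay it gives no change at the digits printed from compound 3 to compound 4 (within the scatter). Methyl in place of methoxy at the same ring position of the phenyl gives no change at the digits printed from compound 2 to compound 4 (within the scatter), while 2-methylphenyl in place of 2,5-difluorophenyl gives a number 2 percentage points lower from compound 1 to compound 4 (within the scatter), so all four aryl groups shown give readings that cannot be told apart. Nothing available here explains these readings.

Going by these compounds, what a pyridyl or cyclohexyl group would do at this position remains open. So does the effect of replacing the neopentyl group with a shorter chain such as ethyl, since that group is the same in all four compounds.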